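A few compounds are considered here, and "the series" means these few. Any claim that something is new, unique, unknown or untested is made for them only; others in the source may bear on it.

Working notes on the series. Compound 2 `COC(=O)c1cccc(C#Cc2ccccc2Nc2ncnc3ccc(Cl)nc23)c1` gives 4200 nM in an assay on isolated protein for inhibition of MAP kinase-interacting serine/threonine-protein kinase 2 (Homo sapiens), read by HTRF, in the presence of a further agent that is not named here; on this read-out higher numbers stand for weaker inhibition and lower numbers for stronger inhibition. Compound 1 `CNC(=O)c1cccc(C#Cc2ccccc2Nc2ncnc3ccc(Cl)nc23)c1` gives 4900 nM in this assay. Among the compounds with values here, the step of a 1.2-fold lower number from compound 1 to compound 2 (0.07 log units; within the scatter) lies within the scatter, so on the two numbers known compound 2 stands within the scatter of compound 1. Compound 3 `CN(C)C(=O)c1cccc(C#Cc2ccccc2Nc2ncnc3ccc(Cl)nc23)c1` is not yet measured; it differs from compound 2 by dimethylamino in place of methoxy on a carbonyl carbon. Within the data shown here, only the step of a 1.2-fold lower number from compound 1 to compound 2 (0.07 log units; within the scatter) bears on this change, and it was flat, so no step beyond the scatter is expected in this assay. A step of a 1.2-fold higher number from compound 2 to compound 3 (0.08 log units; within the scatter) is expected. Compound 3 is estimated at 5000 nM, between 2000 nM and 12000 nM.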

Compound 3, half-maximal inhibitory concentration: > 10000 nM
Compound 3: only a limit was reported (the forecaster's own chance of this, stated with the estimate: 5%); middle value at least 2.0-fold (0.30 log units) away from the limit.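

On the carbonyl carbon the group now matters: dimethylamino in place of methoxy gives an at least 2.3-fold higher number from compound 2 to compound 3 (0.37 log units; beyond the scatter) in this assay, whereas methoxy and methylamino had not separated. Methyl in place of hydrogen on the amide-type nitrogen gives an at least 2.0-fold higher number from compound 1 to compound 3 (0.30 log units; that floor lies within the scatter), so compound 3 is not firmly separated from compound 1. The value of compound 3 is a limit of the assay, not a number: the limit of > 10000 nM in this assay, at which 1 of the 3 values shown sits.

On these data alone, the true size of both steps stays open. Also open, as far as these compounds go, is how a carboxylic acid or the unsubstituted carboxamide on this carbonyl carbon would read.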